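From 4-Chlorophenyl to 2-Chlorophenyl on Compound 3

The source may hold more compounds than are shown below. What is called first, only, known or untested is meant among the compounds shown, and "the series" means these compounds.

In a functional assay on HL-60 cells (Homo sapiens) for inhibition, read by MTT assay, with a stated time of 48 h, tested at 10 uM (on this read-out lower numbers stand for less inhibition of growth and higher numbers for more inhibition of growth at the one concentration tested), compound 1 (`Cc1cc(=O)c2c(O)cc(OC/C=C/c3ccccc3)c([C@H]3CCN(C)C[C@H]3O)c2o1`) gives 21% and compound 2 (`Cc1oc2c([C@H]3CCN(C)C[C@H]3O)c(O)cc(O)c2c(=O)c1C(O)c1c(F)cccc1Cl`) gives 49% while compound 3 (`CN1CC[C@H](c2c(O)cc(O)c3c(=O)cc(/C=C/c4ccc(Cl)cc4)oc23)[C@H](O)C1`) gives 58% in this small set. Compound 3 stands level with compound 2, the gap lying within the scatter, and clearly above compound 1, that gap lying beyond it. Compound 4 (`CN1CC[C@H](c2c(O)cc(O)c3c(=O)cc(/C=C/c4ccccc4Cl)oc23)[C@H](O)C1`) carries 2-chlorophenyl in place of 4-chlorophenyl on a double-bonded chain carbon bound to a double-bonded chain carbon, the two having the same atoms, joined differently. Within the data shown here, no measured pair shows such a change, so the step expected in this assay stays within the scatter, estimated as a number 6 percentage points lower from compound 3 to compound 4 (within the scatter) on this slender basis. Compound 4 is expected at 52% with an estimated range from 35% to 68% in this estimate.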

Compound 4, percent growth inhibition at one concentration: 61%
Compound 4: the middle estimate sits 9 percentage points below what was measured; measured number inside the range.
By their numbers in this assay, from the lowest: compound 1; then compounds 2, 3 and 4 (each within the scatter of the next, the first and the last beyond it).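

Putting 2-chlorophenyl in place of 4-chlorophenyl on a double-bonded chain carbon bound to a double-bonded chain carbon gives, in this assay, a number 3 percentage points higher from compound 3 to compound 4 (within the scatter). At the one concentration tested, this place therefore accepts either chlorophenyl group with no readable difference in growth inhibition. Nothing measured here bears on why the two match.

On these data alone, whether an amine or a carboxylic acid in place of the chlorine would keep this level of inhibition stays open. As far as these compounds go, with a single concentration, it also stays open whether compound 3 and compound 4 would separate at other concentrations.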